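This account rests on a few compounds, and the source may have more. Where it says the series, first, only, none or still open, it means among the compounds named here.

Within the data shown here, in a functional assay on QGY cells (Homo sapiens) for cytotoxicity, read by MTT assay, with a stated time of 48 h (a lower number here means a stronger inhibitor, a higher number a weaker inhibitor), only two numbers exist so far: compound 1 (`CCOC(=O)[C@]1(C(=O)NCc2ccc(C)cc2)C[C@H]1c1cc(OC)c(OC)c(OC)c1`) gives 32100 nM and compound 2 (`COc1cc([C@H]2C[C@]2(CO)C(=O)NCc2ccc(C)cc2)cc(OC)c1OC`) gives 56100 nM under the same conditions. Compound 2 holds the higher of the two numbers, but the gap lies within the scatter of repeated measurements, so the pair cannot be ranked. Compound 3 (`CCOC(=O)[C@]1(C(=O)NCc2ccc(C)cc2)C[C@@H]1c1cc(OC)c(OC)c(OC)c1`) has ethoxycarbonyl in place of hydroxymethyl on a saturated ring carbon of compound 2 (ethoxycarbonyl in place of hydroxymethyl on a saturated ring carbon). Among the measured compounds shown here, no measured pair shows the size of such a change. The nearest guide is compound 1 at 32100 nM in a range that compound 2 shares. The expected change is a 1.6-fold lower number from compound 2 to compound 3 (0.20 log units; within the scatter) in this assay which is a small move toward a lower number and is not expected to go beyond the scatter. The estimate for compound 3 is 35000 nM (expected range 12000 nM to 100000 nM).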

Compound 3, half-maximal inhibitory concentration: > 100000 nM
Compound 3 was reported as a limit; the forecaster's own chance of this, stated with the estimate: 15%; middle value at least 2.8-fold (0.45 log units) away from the limit.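

In this assay compound 3 is reported only as a limit, > 100000 nM, so its steps are floors and not sizes. Ethoxycarbonyl in place of hydroxymethyl on a saturated ring carbon gives an at least 1.7-fold higher number from compound 2 to compound 3 (0.25 log units; that floor lies within the scatter), which by itself shows no clear effect of that change. Among these compounds, the clearer result concerns configuration, since the one stereocentre drawn differently gives an at least 3.1-fold higher number from compound 1 to compound 3 (0.49 log units; beyond the scatter), the only step here beyond the scatter, and that reading rests on the match between the two structures: the fact that compounds 1 and 3 differ only in the configuration as drawn.

As far as these compounds go, how far compound 3 lies past its limit stays unknown, so the true size of both steps is open. From the compounds shown here alone, whether a carboxylic acid or a longer ester chain on that ring carbon would respond to configuration in the same way also stays open.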